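Fluoro for methoxy on a weak piperazine pair

A few compounds are considered here, and "the series" means these few. Any claim that something is new, unique, unknown or untested is made for them only; others in the source may bear on it.

compound 1 `COc1ccccc1-c1n[nH]cc1N1CCCNCC1`: 2230 nM
compound 2 `COc1ccccc1-c1n[nH]cc1N1CCNCC1`: > 10000 nM

In an assay on isolated protein for binding affinity to 5-hydroxytryptamine receptor 3A (Homo sapiens) (a lower number here means a stronger inhibitor, a higher number a weaker inhibitor), compound 1 gives 2230 nM. For compound 2 the assay reports only a limit, > 10000 nM. That limit is the limit of > 10000 nM in this assay, at which 1 of the 2 values shown sits. Compound 2 therefore stands at the weak end of the two numbers shown, with no figure of its own, and its distance from compound 1 cannot be stated as a number.

Compound 3 `Fc1ccccc1-c1n[nH]cc1N1CCNCC1` differs from compound 2 by fluoro in place of methoxy on an aromatic carbon. Among the measured compounds shown here, no step between two measured compounds covers this change, so no measured size can be borrowed for it. In this assay the step from compound 2 to compound 3 is expected to stay within the scatter, a step that the limit leaves unreadable from compound 2 to compound 3. Compound 3 is estimated at 15000 nM, between 4000 nM and 60000 nM, and is most likely to come back again as a limit rather than a number.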

Compound 3, inhibition constant: 1960 nM
For compound 3 the middle estimate is 7.7-fold (0.88 log units) above the measured one; measured number below the stated range.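

In this assay the place on the six-membered aromatic ring, ortho to a large group, proves sensitive to its substituent: fluoro in place of methoxy gives an at least 5.1-fold lower number from compound 2 to compound 3 (0.70 log units; beyond the scatter). Compound 3 therefore supplies a measured number on the core of compound 2, and this one change is enough to bring the value out of the limit. On these data alone, the full size of the step remains unknown because compound 2 has only a limit: the limit of > 10000 nM in this assay, at which 1 of the 3 values shown sits.

As far as these compounds go, whether the gain follows from fluoro in particular or from the loss of methoxy stays open; chloro, methyl or plain hydrogen at this place would separate the two. Also open, from the compounds shown here alone, is whether fluoro in place of methoxy has a similar effect on the core of compound 1.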